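This account rests on a few compounds, and the source may have more. Where it says the series, first, only, none or still open, it means among the compounds named here.

Of the compounds shown here, three of one series have been measured and a fourth awaits its number. Compound 2 `Cc1ccc(Cn2cc(/C=N/NC(=O)Nc3nc4ccc(CN5CCC(C)CC5)cc4s3)c3ccccc32)cc1` is the starting point; in a functional assay on NCI-H460 cells (Homo sapiens) for cytotoxicity, read by MTT assay, with a stated time of 72 h (on this read-out higher numbers stand for weaker inhibition and lower numbers for stronger inhibition), compound 2 gives 410 nM. Compound 1 `CC1CCN(Cc2ccc3nc(NC(=O)N/N=C/c4cn(Cc5cccc(Cl)c5)c5ccccc45)sc3c2)CC1` differs from it by 3-chlorophenyl in place of 4-methylphenyl on a saturated chain carbon bound to an aromatic nitrogen, and in this assay compound 1 gives 280 nM, a step of a 1.5-fold lower number from compound 2 to compound 1 (0.17 log units; within the scatter). Compound 3 `Cc1ccc(Cn2cc(/C=N/NC(=O)Nc3nc4ccc(CN(C)C)cc4s3)c3ccccc32)cc1` keeps the 4-methylphenyl of compound 2 but alters the core by dimethylamino in place of 4-methylpiperidin-1-yl on a saturated chain carbon bound to an aromatic carbon; in this assay compound 3 gives 200 nM, which is a 2.1-fold lower number from compound 2 to compound 3 (0.31 log units; beyond the scatter).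

Compound 4 `CN(C)Cc1ccc2nc(NC(=O)N/N=C/c3cn(Cc4cccc(Cl)c4)c4ccccc34)sc2c1` is built from compound 3 by 3-chlorophenyl in place of 4-methylphenyl on a saturated chain carbon bound to an aromatic nitrogen. This is the same change already seen between compound 2 and compound 1, made here on the core of compound 3 rather than that of compound 2. Since that earlier step stayed within the scatter, the expectation for compound 4 is a small change as well, resting on compound 3 at 200 nM and the step of a 1.5-fold lower number from compound 2 to compound 1 (0.17 log units; within the scatter). The expected step is a 1.3-fold lower number from compound 3 to compound 4 (0.12 log units; within the scatter). For compound 4 the estimate in this assay is 150 nM, with a likely range from 70 nM to 320 nM.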

Compound 4, half-maximal inhibitory concentration: 420 nM
Estimate against measurement, compound 4: 2.8-fold (0.45 log units) below; the measured number lies above the stated range.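

In this assay, 3-chlorophenyl in place of 4-methylphenyl on the core of compound 3 gives a 2.1-fold higher number from compound 3 to compound 4 (0.32 log units; beyond the scatter), and so the change did not carry over unaltered from the core of compound 2: the same change on two cores in this assay, a 1.5-fold lower number (0.17 log units; within the scatter) from compound 2 to compound 1 and a 2.1-fold higher number (0.32 log units; beyond the scatter) from compound 3 to compound 4, 3.1-fold (0.49 log units) apart, beyond the scatter of two such steps. Dimethylamino in place of 4-methylpiperidin-1-yl, read on the compounds that carry 3-chlorophenyl, gives a 1.5-fold higher number from compound 1 to compound 4 (0.18 log units; within the scatter), and this step also fails to match its counterpart: the same change on two cores in this assay, a 2.1-fold lower number (0.31 log units; beyond the scatter) from compound 2 to compound 3 and a 1.5-fold higher number (0.18 log units; within the scatter) from compound 1 to compound 4, 3.1-fold (0.49 log units) apart, beyond the scatter of two such steps. Among these four compounds, then, the effect of each change depends on the group present at the other place, but the numbers do not show why, nor whether this holds for any compound outside the four.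

The compounds shown leave open whether the shift belongs to the chlorine or to its position, which a 3-methylphenyl or a 4-chlorophenyl on the same chain carbon would help to separate. They also leave open how a further amine such as morpholin-4-yl would behave with each of the two benzyl groups.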